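A few compounds are considered here, and "the series" means these few. Any claim that something is new, unique, unknown or untested is made for them only; others in the source may bear on it.

Compound 1 `CCS(=O)(=O)Nc1ccc(NC(=O)c2ccc(Cl)cc2)cc1OC` and compound 2 `CCS(=O)(=O)Nc1ccc(NC(=O)c2ccc(Cl)c([N+](=O)[O-])c2)cc1OC` share one core and were run in an ADME assay on HEK293 cells (Homo sapiens) for cytotoxicity, read by MTT assay, with a stated time of 48 h; a lower number here means a stronger inhibitor, a higher number a weaker inhibitor. For compound 1 the result in this assay is a limit of the assay, > 250000 nM, not a number. Compound 1 sits at the limit of > 250000 nM in this assay, at which 1 of the 3 values shown sits. In this assay compound 2 gives 63700 nM. The change nitro in place of hydrogen on an aromatic carbon therefore brings an at least 3.9-fold lower number from compound 1 to compound 2 (0.59 log units; beyond the scatter). Compound 3 `CS(=O)(=O)Nc1ccc(NC(=O)c2ccc(Cl)cc2)cc1F` rests on another core; how the two cores differ from those of compound 1 is not broken down here. In this assay compound 3 gives 216000 nM. Compound 4 `CS(=O)(=O)Nc1ccc(NC(=O)c2ccc(Cl)c([N+](=O)[O-])c2)cc1F` carries the same change, (nitro in place of hydrogen on an aromatic carbon), on the core of compound 3. A step of similar size is expected, a 3.6-fold lower number from compound 3 to compound 4 (0.56 log units; beyond the scatter), resting on the measured step of an at least 3.9-fold lower number from compound 1 to compound 2 (0.59 log units; beyond the scatter) made on the core of compound 1. Compound 4 is thus estimated at 60000 nM, expected between 25000 nM and 150000 nM.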

Compound 4, half-maximal inhibitory concentration: 23100 nM
Beside the measured number, compound 4's estimate is 2.6-fold (0.41 log units) above it, and the stated range ends above it.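

In this assay nitro in place of hydrogen on an aromatic carbon brings a 9.4-fold lower number from compound 3 to compound 4 (0.97 log units; beyond the scatter) and the number goes the same way on the core of compound 1. Compound 1 gives > 250000 nM as a limit of the assay and not as a number. The direction of the change thus carries across these two cores, but whether its size carries too stays unsettled: the same change on two cores in this assay, an at least 3.9-fold lower number (0.59 log units; beyond the scatter) from compound 1 to compound 2 and a 9.4-fold lower number (0.97 log units; beyond the scatter) from compound 3 to compound 4; the limit leaves it open whether they differ.

The compounds shown leave open how an amine or a carboxylic acid in place of the nitro group would compare. They also leave open whether the step holds on a further core, such as one with a longer chain in place of the ethyl group.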